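A Second Fluoro Step on a Shared Core

This account rests on a few compounds, and the source may have more. Where it says the series, first, only, none or still open, it means among the compounds named here.

Three compounds have been measured in a functional assay on HeLa cells (Homo sapiens) for cytotoxicity, read by MTT assay, with a stated time of 2 days, tested at 100 uM; on this read-out lower numbers stand for a stronger effect and higher numbers for a weaker effect at the one concentration tested:
Compound 1, `CC(=O)c1cc(-c2ccc(F)cc2)cc2cc(-c3ccccc3)[nH]c12`, gives 24.8%.
Compound 2, `CC(=O)c1cc(-c2ccc(F)cc2)cc2cc(-c3ccc(F)cc3)[nH]c12`, gives 9.31%.
Compound 3, `CC(=O)c1cc(/C=C/c2ccccc2)cc2cc(-c3ccc(F)cc3)[nH]c12`, gives 24.3%.

The change from compound 1 to compound 2 is fluoro in place of hydrogen on an aromatic carbon, and it made a number 15.5 percentage points lower from compound 1 to compound 2 (beyond the scatter). Compound 3 carries the same 4-fluorophenyl as compound 2, but the difference between its core and that of compound 1 is not broken down here; the step of a number 15 percentage points higher from compound 2 to compound 3 (beyond the scatter) shows where it ends up, and against compound 1 its value lies within the scatter.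

Compound 4, `CC(=O)c1cc(/C=C/c2ccc(F)cc2)cc2cc(-c3ccc(F)cc3)[nH]c12`, is not yet measured. Its change from compound 3 is fluoro in place of hydrogen on an aromatic carbon, the same change as from compound 1 to compound 2, cut one bond further out reading 2-phenylethenyl to 2-(4-fluorophenyl)ethenyl rather than phenyl to 4-fluorophenyl. Because the earlier occurrence gave a number 15.5 percentage points lower from compound 1 to compound 2 (beyond the scatter), a lowering of similar size is expected, though with one precedent the step is uncertain: the expected step is a number 11.3 percentage points lower from compound 3 to compound 4 (beyond the scatter). Compound 4 is estimated at 13%, between 4% and 24%.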

Compound 4, a percentage reported as activity, at one concentration (the size of the read-out at that concentration, not a potency): 20.3%
The estimate for compound 4 lay 7.3 percentage points below the measured number; the range from low to high includes it.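

In this assay, fluoro in place of hydrogen on the 2-phenylethenyl group gave a number 4 percentage points lower from compound 3 to compound 4 (within the scatter), so this step alone does not separate the two compounds. Set beside the earlier step, it does not differ by more than two such steps can scatter: the same change on two cores in this assay, a number 15.5 percentage points lower (beyond the scatter) from compound 1 to compound 2 and a number 4 percentage points lower (within the scatter) from compound 3 to compound 4, 11.5 percentage points apart, within the scatter of two such steps. This shows that the two occurrences are compatible with one shared effect but does not show that the lowering seen on the core of compound 1 carries over, since a real loss of it on the second core is not excluded either, while the exchange of groups itself still counts, with 2-(4-fluorophenyl)ethenyl in place of 4-fluorophenyl giving a number 11 percentage points higher from compound 2 to compound 4 (beyond the scatter).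

The compounds shown leave open whether another group in the same place, such as chloro or methoxy, would follow the fluoro steps. They also leave open how these steps would read on a core carrying an amine or a carboxylic acid, and at concentrations other than the single one tested.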